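Three weak inhibitors and one untested analogue

A few compounds are considered here, and "the series" means these few. Any claim that something is new, unique, unknown or untested is made for them only; others in the source may bear on it.

Three compounds have been measured in a functional assay, with a stated time of 20 min; a higher number here means a weaker inhibitor, a lower number a stronger inhibitor:

compound 1 `CCOC(=O)c1cnn(-c2nc(-c3ccccc3F)c(C#N)c(=O)n2C)c1N` gives 69 ug/mL
compound 2 `CSc1nc(-c2cccs2)c(C#N)c(=O)n1C` gives 71 ug/mL
compound 3 `CSc1nc(-c2ccccc2O)c(C#N)c(=O)n1C` gives 52 ug/mL

Compound 1 stands second highest of these three numbers; its nearest neighbour is compound 2 and its furthest is compound 3, and both differences lie within the scatter, so the three read as indistinguishable. Compound 4 `CCOC(=O)c1cnn(-c2nc(-c3ccc(N(C)C)cc3)c(C#N)c(=O)n2C)c1N` has not been measured. It differs from compound 1 by 4-(dimethylamino)phenyl in place of 2-fluorophenyl on an aromatic carbon. Within the data shown here, no comparable step between measured compounds exists, so nothing shows how this change moves the read-out in this assay; with only equal-looking numbers at hand, the expected step of a 1.2-fold lower number from compound 1 to compound 4 (0.06 log units; within the scatter) is none beyond the scatter. Compound 4 is therefore estimated at 60 ug/mL, with a range from 30 ug/mL to 130 ug/mL.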

Compound 4, half-maximal inhibitory concentration: 98 ug/mL
Compound 4: the middle estimate sits 1.6-fold (0.21 log units) below what was measured; the measured number falls inside the stated range.
By their numbers in this assay, from the lowest: compounds 3, 1, 2 and 4 (each within the scatter of the next).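

In this assay, placing 4-(dimethylamino)phenyl instead of 2-fluorophenyl on the aromatic carbon ortho to a cyano group gives a 1.4-fold higher number from compound 1 to compound 4 (0.15 log units; within the scatter) and so no change that can be told from the scatter. This position therefore accepts the larger group, with its added hydrogen-bond acceptor, without a clear loss or gain. No measured property of either group bears on this result. Left open is whether plain phenyl would separate the effects of removing the fluorine and adding the dimethylamino group. Also open, going by these compounds, is whether a carboxylic acid on this ring, or an amine in its place, would move the number beyond the scatter.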